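The source may report more compounds than this note shows. Statements on the series, on what has been measured and on what is new or still open speak of the compounds shown alone.

Compound 1 `CN(C)CCCNc1nc(-c2ccc(NC(=O)Nc3ccc(Cl)cc3)cc2)nc2c(Cl)c(Cl)sc12` carries a urea whose far ring is 4-chlorophenyl; in a functional assay on MDA-MB-231 cells (Homo sapiens) for cytotoxicity, read by MTT assay, with a stated time of 72 h (on this read-out lower numbers stand for stronger inhibition and higher numbers for weaker inhibition), compound 1 gives 1160 nM. Compound 2 `CN(C)CCCNc1nc(-c2ccc(NC(=O)Nc3ccccc3Cl)cc2)nc2c(Cl)c(Cl)sc12` differs by 2-chlorophenyl in place of 4-chlorophenyl on an amide-type nitrogen, and in this assay compound 2 gives 1560 nM, so the step of a 1.3-fold higher number from compound 1 to compound 2 (0.13 log units; within the scatter) is small. Compound 3 `CN(C)CCNc1nc(-c2ccc(NC(=O)Nc3ccc(Cl)cc3)cc2)nc2ccsc12` has a different core, and the difference between the two cores is not broken down here; in this assay compound 3 gives 310 nM, the lowest of the three numbers. Compound 4 `CN(C)CCNc1nc(-c2ccc(NC(=O)Nc3ccccc3Cl)cc2)nc2ccsc12` is not yet measured and differs from compound 3 by 2-chlorophenyl in place of 4-chlorophenyl on an amide-type nitrogen, the same change at the same place as between compound 1 and compound 2. Because a 1.3-fold higher number from compound 1 to compound 2 (0.13 log units; within the scatter) stayed within the scatter, the step of a 1.4-fold higher number from compound 3 to compound 4 (0.13 log units; within the scatter) is expected to be similarly small. Compound 4 is therefore estimated at 420 nM in this assay, likely between 200 nM and 900 nM.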

Compound 4, half-maximal inhibitory concentration: 550 nM
Beside the measured number, compound 4's estimate is 1.3-fold (0.12 log units) below it; the range from low to high includes it.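

In this assay, putting 2-chlorophenyl in place of 4-chlorophenyl on an amide-type nitrogen gives a 1.8-fold higher number from compound 3 to compound 4 (0.25 log units; within the scatter), and the two steps for this change do not differ: the same change on two cores in this assay, a 1.3-fold higher number (0.13 log units; within the scatter) from compound 1 to compound 2 and a 1.8-fold higher number (0.25 log units; within the scatter) from compound 3 to compound 4, 1.3-fold (0.12 log units) apart, within the scatter of two such steps. In these two pairs, then, the change carries from the core of compound 1 to the core of compound 3 with a small step each time. Among the compounds shown here, this does not show that it would stay small on any other core or in any other assay, as the comparison rests on only two pairs.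

As far as these compounds go, it remains open whether a far ring such as 3-chlorophenyl, 4-methoxyphenyl or unsubstituted phenyl would behave alike. From the compounds shown here alone, compound 1 and compound 3 differ in more than one place, so the contribution of each difference also remains open.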